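Extending the Side Chain of Compound 2

The source may hold more compounds than are shown below. What is called first, only, known or untested is meant among the compounds shown, and "the series" means these compounds.

Among the compounds with values here, in a toxicity assay on L02 cells (Homo sapiens) for cytotoxicity, read by MTT assay, with a stated time of 72 h (on this read-out lower numbers stand for stronger inhibition and higher numbers for weaker inhibition), compound 2 `O=C1c2c[n+]([O-])c3ccccc3c2C(=O)c2c1c1ccccc1n2CCN1CCCC1` gives 930 nM, the higher of the two numbers so far, and compound 1 `CN1CCN(CCCCn2c3c(c4ccccc42)C(=O)c2c[n+]([O-])c4ccccc4c2C3=O)CC1` gives 80 nM. Compound 3 `O=C1c2c[n+]([O-])c3ccccc3c2C(=O)c2c1c1ccccc1n2CCCCN1CCNCC1` carries 2-(piperazin-1-yl)ethyl in place of pyrrolidin-1-yl on a saturated chain carbon, two bonds along the chain from an aromatic nitrogen. Within the data shown here, only one measured step bears on this, at that same place: the large 12-fold higher number from compound 1 to compound 2 (1.07 log units; beyond the scatter), where compound 1 carries 2-(4-methylpiperazin-1-yl)ethyl. Most of that step is expected to reverse in this assay, giving an expected drop of a 6.2-fold lower number from compound 2 to compound 3 (0.79 log units; beyond the scatter). Compound 3 is estimated at 150 nM, within 50 nM to 450 nM.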

Compound 3, half-maximal inhibitory concentration: 1380 nM
Compound 3: middle estimate off by 9.2-fold (0.96 log units), on the low side; measured number above the stated range.
By their numbers in this assay, from the lowest: compound 1; then compounds 2 and 3 (each within the scatter of the next).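

In this assay the piperazine on the longer chain does not by itself bring the low number of compound 1 (a 1.5-fold higher number from compound 2 to compound 3 (0.17 log units; within the scatter)). The large change comes instead with hydrogen in place of methyl on an amine nitrogen in a ring (a 17-fold higher number from compound 1 to compound 3 (1.24 log units; beyond the scatter)), so among these compounds that one methyl separates compound 1 from compound 3. No measurement shown explains why it counts for so much.

As far as these compounds go, whether an ethyl or acetyl group on that ring nitrogen would keep the low number remains open. So does whether the methyl has the same effect on a shorter chain.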